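The source may report more compounds than this note shows. Statements on the series, on what has been measured and on what is new or still open speak of the compounds shown alone.

The account follows the step from compound 1 `Cc1ccc(N2CCN(C(=O)c3oc(C)nc3-c3ccccc3)CC2)cc1` to compound 4 `CC(=O)Nc1cccc(N2CCN(C(=O)c3oc(C)nc3-c3ccccc3)CC2)c1` in a functional assay on HL-60 cells (Homo sapiens) for inhibition, read by MTT assay, with a stated time of 72 h; on this read-out lower numbers stand for stronger inhibition and higher numbers for weaker inhibition. In this assay compound 1 reaches only > 1000 nM, which is a limit of the assay and not a number, so that the limit of > 1000 nM in this assay, at which 1 of the 3 values shown sits, marks where compound 1 stands. Two other compounds share the read-out. Compound 2 `CCC[C@H](Nc1nc(-c2ccc(NC(=O)NCC)c(OC)c2)ncc1C)c1cccnc1`, built on a different core, gives 112 nM in this assay. Compound 3 `Cc1nc(-c2ccccc2)c(C(=O)N2CCN(c3ccc(C(=O)C(C)C)cc3)CC2)o1` shares the shared core; in this assay compound 3 is reported as "not active" (no number reported). No step between two measured compounds that differ in one place is shown, so nothing is known of how changes on this core move the read-out. The change to compound 4 is 3-acetamidophenyl in place of 4-methylphenyl on an amine nitrogen in a ring. With compound 1 at a limit and compound 3 without a number, the expected step in this assay is a step that the limit leaves unreadable from compound 1 to compound 4, none beyond the scatter, with another limit the most likely outcome. Compound 4 is therefore estimated at 3000 nM, within 800 nM to 20000 nM.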

Compound 4, half-maximal inhibitory concentration: 329 nM
Estimate against measurement, compound 4: 9.1-fold (0.96 log units) above; the whole stated range lies above it.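

In this assay, among the compounds shown here, 3-acetamidophenyl in place of 4-methylphenyl on an amine nitrogen in a ring brings an at least 3.0-fold lower number from compound 1 to compound 4 (0.48 log units; beyond the scatter), the first readable step on the shared core. The group at this position can therefore move the read-out beyond the scatter, which compound 1 and compound 3 could not show, as neither has a single number. Compound 1 remains a limit of the assay and not a number, and the true size of the step stays open because of that: the limit of > 1000 nM in this assay, at which 1 of the 4 values shown sits.

The single step changes both the group and where it stands on the aromatic ring, so the compounds shown do not separate the acetamido group from its placement. As far as these compounds go, how a simple amine or a carboxylic acid on that ring would read also remains open.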